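Chloro Added to the Dimethylphenyl Ring of Compound 2

The compounds below may be only part of what the source reports. "The series", "measured", "known", "first", "only" and "open" are said of these compounds alone.

Of the compounds shown here, two sharing a benzimidazole-type core have been measured in an ADME assay on microsomes from liver for inhibition of cytochrome P450 2B1 (Rattus norvegicus); on this read-out lower numbers stand for stronger inhibition and higher numbers for weaker inhibition. Compound 1 `Cc1ccc2[nH]c(C)nc2c1` gives 479000 nM, while compound 2 `Cc1cc(C)cc(OCc2nc3ccccc3[nH]2)c1` gives 25700 nM. On these two numbers compound 2 stands lowest, and the gap to compound 1 lies beyond the scatter of repeated measurements, so compound 2 is the stronger inhibitor of the pair.

Compound 3 `Cc1cc(OCc2nc3ccccc3[nH]2)cc(C)c1Cl` has not yet been measured in this assay. It differs from compound 2 in one place: chloro in place of hydrogen on an aromatic carbon. Among the compounds with values here, no measured pair shows this change, so its effect can only be estimated. A modest step toward stronger inhibition, beyond the scatter, is expected from compound 2 to compound 3, as a 2.6-fold lower number from compound 2 to compound 3 (0.41 log units; beyond the scatter). Compound 3 is therefore estimated to give 10000 nM in this assay, with a range from 4000 nM to 30000 nM.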

Compound 3, half-maximal inhibitory concentration in the cytochrome P450 2B1 assay: 30200 nM
The estimate for compound 3 lay 3.0-fold (0.48 log units) below the measured number; measured number above the stated range.
By their numbers in the cytochrome P450 2B1 assay, from the lowest: compounds 2 and 3 (each within the scatter of the next); then compound 1.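

Within the data shown here, this is the first step between two measured compounds that differ in one place, and it gives a direct reading of this position. In the cytochrome P450 2B1 assay, chloro in place of hydrogen on the aromatic carbon ortho to two methyl groups and para to a large group gives a 1.2-fold higher number from compound 2 to compound 3 (0.07 log units; within the scatter), so this position takes the chloro with no readable shift in inhibition. In a physicochemical assay for lipophilicity (on this read-out higher numbers stand for higher lipophilicity and lower numbers for lower lipophilicity), compound 2 gives 3.5 and compound 3 gives 4.43. In the physicochemical assay, the same change does register, and on that read-out a higher lipophilicity at this position came with no readable shift in inhibition: the measured partition coefficient of compound 2, 3.5, and of compound 3, 4.43, a number 0.93 log units higher (beyond the scatter)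

The compounds shown leave open whether a different group on this aromatic carbon, such as an amine, a carboxylic acid or a longer chain, would move inhibition of the enzyme in either direction, since chloro is the only replacement for hydrogen seen here. They also leave open whether chloro would behave in the same way on another carbon of this ring or with the two methyl groups replaced, as this single step comes from one pair of compounds.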